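The source may report more compounds than this note shows. Statements on the series, on what has been measured and on what is new or still open speak of the compounds shown alone.

Three compounds with the shared core have been run in an ADME assay on liver for metabolic stability, with Liver microsome (Homo sapiens) as the target, read by LC-MS, using microsomes; on this read-out higher numbers stand for fast clearance and lower numbers for slow clearance. Compound 1 `CC(C)(C)[C@@H](O)C(=O)N1OCC[C@H]1C(=O)NCc1cc(Cl)ccc1-n1cnnn1` sits at a limit of this assay, giving < 12 mL.min-1.g-1. Compound 3 `O=C(NCc1cc(Cl)ccc1-n1cnnn1)[C@@H]1CCON1C(=O)[C@H](O)c1ccccc1` also sits at a limit, giving < 12 mL.min-1.g-1. The two differ by phenyl in place of tert-butyl on a saturated chain carbon bound to a carbonyl carbon and an oxygen on a saturated carbon, and the resulting step that the two limits leave unreadable from compound 1 to compound 3 has no readable size, since both ends are limits (the limit of < 12 mL.min-1.g-1 in this assay, at which 2 of the 3 values shown sit). Among the measured compounds shown here, compound 2 `CC(C)(C)C[C@@H](O)C(=O)N1C[C@@H]2C[C@@H]2[C@H]1C(=O)NCc1cc(Cl)ccc1-n1cnnn1` is the only member with a number, giving 20 mL.min-1.g-1 in this assay; how its core differs from that of compound 1 is not broken down here. Compound 4 `O=C(NCc1cc(Cl)ccc1-n1cnnn1)[C@@H]1[C@H]2C[C@H]2CN1C(=O)[C@H](O)Cc1ccccc1` carries the same kind of change against compound 2, namely (phenyl in place of tert-butyl on a saturated chain carbon, two bonds along the chain from a carbonyl carbon and an oxygen on a saturated carbon), the place now being two bonds along the chain from a carbonyl carbon rather than bound to it. The step of a 1.1-fold higher number from compound 2 to compound 4 (0.04 log units; within the scatter) is expected to stay within the usual scatter, resting only on the value of compound 2, 20 mL.min-1.g-1. Compound 4 is therefore estimated at 22 mL.min-1.g-1, between 10 mL.min-1.g-1 and 50 mL.min-1.g-1.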

Compound 4, intrinsic clearance in microsomes: 96 mL.min-1.g-1
Compound 4: middle estimate off by 4.4-fold (0.64 log units), on the low side; the whole stated range lies below it.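

In this assay, phenyl in place of tert-butyl, on a saturated chain carbon two bonds along the chain from a carbonyl carbon, gives a 4.8-fold higher number from compound 2 to compound 4 (0.68 log units; beyond the scatter). On the core of compound 1, where the same kind of change sits on a chain carbon bound to the carbonyl carbon, the step to compound 3 cannot be read, since both ends are limits of the assay: the limit of < 12 mL.min-1.g-1 in this assay, at which 2 of the 4 values shown sit. The change therefore has one readable size, on one core, and nothing here shows whether that size carries over to another core.

The compounds shown leave open how an amine or a carboxylic acid in place of phenyl would read in this assay. As far as these compounds go, a longer chain at this place also remains open.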